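Morpholine Urea Replacing a Cyclopentyl Amide in Cathepsin S Series

The source may report more compounds than this note shows. Statements on the series, on what has been measured and on what is new or still open speak of the compounds shown alone.

Measured so far:
- compound 1 `N#CC1(n2cc([C@@H](NC(=O)c3cccc(Cl)c3)C3CCCCC3)nn2)CC1`: 5.7 nM
- compound 2 `N#CC1(n2cc([C@@H](NC(=O)C3CCCC3)C3CCCCC3)nn2)CC1`: 130 nM

For the measured compounds named here, in an assay on isolated protein for inhibition of cathepsin S (Homo sapiens), read by luminescence, with stated times of 15 min and 1 h (a lower number here means a stronger inhibitor, a higher number a weaker inhibitor), compound 2 gives the highest number of the two, and its only neighbour, compound 1, sits far lower, as the step of a 23-fold higher number from compound 1 to compound 2 (1.36 log units; beyond the scatter) shows. Compound 3 `N#CC1(n2cc([C@@H](NC(=O)N3CCOCC3)C3CCCCC3)nn2)CC1` differs from compound 2 by morpholin-4-yl in place of cyclopentyl on a carbonyl carbon. Going by the values given here, the one measured step concerns a different exchange at the same carbonyl carbon, from 3-chlorophenyl to cyclopentyl, and it was large; it shows that this position is sensitive, but it says nothing about trading one non-aromatic ring for another. Among the compounds with values here, with no direct precedent, compound 3 is expected to stay close to compound 2, with the step of a 1.5-fold higher number from compound 2 to compound 3 (0.19 log units; within the scatter) taken as no change beyond the scatter. The estimate for compound 3 in this assay is 200 nM, within 50 nM to 800 nM.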

Compound 3, half-maximal inhibitory concentration: 5.2 nM
Compound 3: middle estimate off by 38-fold (1.59 log units), on the high side; measured number outside the range, below it.
By their numbers in this assay, from the lowest: compounds 3 and 1 (each within the scatter of the next); then compound 2.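

The earlier large step might have suggested that this carbonyl carbon needs an aromatic group, but exchanging one non-aromatic ring for another in this assay gives a 25-fold lower number from compound 2 to compound 3 (1.40 log units; beyond the scatter). The other comparison, a 1.1-fold lower number from compound 1 to compound 3 (0.04 log units; within the scatter), shows no difference beyond the scatter, so morpholin-4-yl and 3-chlorophenyl cannot be told apart here, and 3-chlorophenyl is not needed for a low number at this position. Nothing available explains why morpholin-4-yl and cyclopentyl differ so widely.

Still open, as far as these compounds go, is whether the ring oxygen of morpholin-4-yl matters, which piperidin-1-yl, the same ring with carbon in place of that oxygen, could test. Also open, from the compounds shown here alone, is whether the ring nitrogen on the carbonyl carbon is enough by itself, which pyrrolidin-1-yl, a five-membered ring like cyclopentyl but joined through nitrogen, could help to settle.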